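Exchanging One Ring at the Same Place

A few compounds are considered here, and "the series" means these few. Any claim that something is new, unique, unknown or untested is made for them only; others in the source may bear on it.

In a functional assay on HeLa cells (Homo sapiens) for cytotoxicity, read by ELISA, with a stated time of 4 days (on this read-out higher numbers stand for weaker inhibition and lower numbers for stronger inhibition), compound 2 `Clc1ccc(-c2cc(-c3ccoc3)cc(-c3ccc(Cl)s3)n2)cc1` gives 16500 nM, within the scatter of compound 1 `Clc1ccc(-c2cc(-c3ccoc3)cc(-c3ccco3)n2)s1` at 22700 nM. Compound 3 `Clc1ccc(-c2cc(-c3ccoc3)cc(-c3ccccn3)n2)s1` keeps the rest of compound 2 but carries pyridin-2-yl in place of 4-chlorophenyl (pyridin-2-yl in place of 4-chlorophenyl on an aromatic carbon). Going by the values given here, only one measured step bears on this place: furan-2-yl gave way to 4-chlorophenyl, with a 1.4-fold lower number from compound 1 to compound 2 (0.14 log units; within the scatter). That step stayed within the scatter, so no clear move in either direction is expected here, and the estimated step is a 1.1-fold lower number from compound 2 to compound 3 (0.04 log units; within the scatter). Compound 3 is expected at 15000 nM, with an estimated range of 5000 nM to 40000 nM.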

Compound 3, half-maximal inhibitory concentration: 21600 nM
The estimate for compound 3 lay 1.4-fold (0.16 log units) below the measured number; the measured number falls inside the stated range.
By their numbers in this assay, from the lowest: compounds 2, 3 and 1 (each within the scatter of the next).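

Pyridin-2-yl adds a ring nitrogen and a hydrogen-bond acceptor that 4-chlorophenyl lacks, yet in this assay the exchange gives a 1.3-fold higher number from compound 2 to compound 3 (0.12 log units; within the scatter) and no clear difference. Measured against furan-2-yl, a 1.1-fold lower number from compound 1 to compound 3 (0.02 log units; within the scatter) also stays within the scatter, so these three rings cannot be told apart at this place. No available measurement explains why the exchanges leave the number so little changed.
From the compounds shown here alone, all three groups are aromatic rings, so it remains open whether an amine, a carboxylic acid or a longer chain at this place would shift the number beyond the scatter.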